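A few compounds are considered here, and "the series" means these few. Any claim that something is new, unique, unknown or untested is made for them only; others in the source may bear on it.

In a functional assay on A549 cells (Homo sapiens) for antiproliferative activity, read by MTT assay, with a stated time of 48 h (on this read-out higher numbers stand for weaker inhibition and lower numbers for stronger inhibition), compound 1 `O=C(/C=C/c1cc(Br)cc(Br)c1Oc1c([N+](=O)[O-])cc(C(F)(F)F)cc1[N+](=O)[O-])c1ccc(F)cc1` gives 120 ug/mL and compound 2 `O=C(/C=C/c1cccc(Br)c1Oc1c([N+](=O)[O-])cc(C(F)(F)F)cc1[N+](=O)[O-])c1ccc(F)cc1` gives 26.3 ug/mL, the lower of the two numbers. Compound 3 `O=C(/C=C/c1cccc(Br)c1Oc1c([N+](=O)[O-])cc(C(F)(F)F)cc1[N+](=O)[O-])c1ccc(Cl)cc1` differs from compound 2 by chloro in place of fluoro on an aromatic carbon, para to a large group. Among the measured compounds shown here, the only measured step, a 4.6-fold lower number from compound 1 to compound 2 (0.66 log units; beyond the scatter), is hydrogen in place of bromo on an aromatic carbon and does not measure this exchange, so the expectation stays anchored on compound 2 at 26.3 ug/mL. An estimated 1.1-fold lower number from compound 2 to compound 3 (0.02 log units; within the scatter) is expected, with no change beyond the scatter. For compound 3 the expected value is 25 ug/mL, within an estimated range of 11 ug/mL to 60 ug/mL.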

Compound 3, half-maximal inhibitory concentration: 16.5 ug/mL
Estimate against measurement, compound 3: 1.5-fold (0.18 log units) above; the range from low to high includes it.
By their numbers in this assay, from the lowest: compounds 3 and 2 (each within the scatter of the next); then compound 1.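

In this assay, 4-chlorophenyl in place of 4-fluorophenyl gives a 1.6-fold lower number from compound 2 to compound 3 (0.20 log units; within the scatter), so this exchange, para to a large group, leaves the read-out within the scatter. Among the compounds shown here, this is the first measured step at this position, and it contrasts with the change beyond the scatter seen on removing bromo, a 4.6-fold lower number from compound 1 to compound 2 (0.66 log units; beyond the scatter). No evidence is available that bears on this result. Going by these compounds, whether an amine or a carboxylic acid at this position would hold the number remains open. Also open, on these data alone, is whether chloro in place of fluoro would read the same with the extra bromo of compound 1 present.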